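Swapping an amide for a sulfonamide on a cathepsin S series

A few compounds are considered here, and "the series" means these few. Any claim that something is new, unique, unknown or untested is made for them only; others in the source may bear on it.

Compound 1 `Cc1cccc(C(=O)Nc2cccc(/C=C/C(=O)c3nc4ccccc4[nH]3)c2)c1` was tested in an assay on isolated protein for inhibition of cathepsin S (Homo sapiens), read by fluorescence, with stated times of 15 min and 30 min, tested at 5 uM (a higher number here means more inhibition at the concentration tested (going by the name of the read-out), a lower number less inhibition), and gives 45.2%, the lowest of the three measured numbers. Compound 3 `Cc1cccc(S(=O)(=O)Nc2cccc(/C=C/C(=O)c3nc4ccccc4[nH]3)c2)c1` gives 50.1%, a change a number 4.9 percentage points higher from compound 1 to compound 3 (within the scatter), so these two cannot be told apart. Compound 2 `O=C(/C=C/c1cccc(NS(=O)(=O)c2ccc(Cl)cc2)c1)c1nc2ccccc2[nH]1` gives 89.4%, a change a number 44.2 percentage points higher from compound 1 to compound 2 (beyond the scatter), and from compound 2 to compound 3 the number moves a number 39.3 percentage points lower from compound 2 to compound 3 (beyond the scatter). Compound 4 `Cc1ccc(S(=O)(=O)Nc2cccc(/C=C/C(=O)c3nc4ccccc4[nH]3)c2)cc1` differs from compound 1 by (4-methylphenyl)sulfonyl in place of (3-methylphenyl)carbonyl on a nitrogen on an aromatic ring. Both measured steps bear on this: the same exchange of carbonyl for sulfonyl gave little in compound 3 but a large gain in compound 2. A moderate rise is therefore expected, a number 16.8 percentage points higher from compound 1 to compound 4 (beyond the scatter). Compound 4 is estimated at 62%, with a range of 42% to 85%.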

Compound 4, a percentage reported as inhibition, at one concentration (the size of the read-out at that concentration, not a potency): 22%
Compound 4: the middle estimate sits 40 percentage points above what was measured; measured number below the stated range.
By their numbers in this assay, from the lowest: compound 4; then compounds 1 and 3 (each within the scatter of the next); then compound 2.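

On a sulfonyl sulfur, the place of the methyl alone matters: 4-methylphenyl in place of 3-methylphenyl gives a clear fall (a number 28.1 percentage points lower from compound 3 to compound 4 (beyond the scatter)). Methyl in place of chloro on an aromatic carbon gives a much larger fall (a number 67.4 percentage points lower from compound 2 to compound 4 (beyond the scatter)), and sulfonyl in place of carbonyl does not by itself raise the number, since the step from the amide goes down (a number 23.2 percentage points lower from compound 1 to compound 4 (beyond the scatter)). No measurement here explains these shifts.

Going by these compounds, whether 4-methoxyphenyl or 4-fluorophenyl on the sulfonyl sulfur would sit nearer compound 2 or compound 4 remains open. So does whether 3-chlorophenyl there would match compound 2.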